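A few compounds are considered here, and "the series" means these few. Any claim that something is new, unique, unknown or untested is made for them only; others in the source may bear on it.

The measured compounds in a functional assay on MDA-MB-231 cells (Homo sapiens) for inhibition, read by CCK-8 assay, with a stated time of 48 h; a higher number here means a weaker inhibitor of growth, a lower number a stronger inhibitor of growth:
compound 1 `Cc1ccccc1Nc1nc(Nc2ccccn2)ncc1Cl` gives 11200 nM;
compound 2 `Cc1ccccc1Nc1nc(Nc2ccc(N3CCN(C)CC3)cc2)ncc1Cl` gives 7020 nM;
compound 3 `CN1CCN(c2ccc(Nc3ncc(Cl)c(Nc4ccccc4)n3)nc2)CC1` gives 37400 nM.

Among these three, compound 3 stands at the highest number, beyond the scatter from both compound 1 and compound 2, so it is the weakest inhibitor of growth of the three. Compound 4 `CC(C)c1cccc(Nc2nc(Nc3ccc(N4CCN(C)CC4)cn3)ncc2Cl)c1` differs from compound 3 in one place: isopropyl in place of hydrogen on an aromatic carbon. Within the data shown here, no measured pair shows this change, so its effect is not known from these data. A modest move toward a lower number is expected, though one that may stay within the scatter, giving an expected step of a 1.9-fold lower number from compound 3 to compound 4 (0.27 log units; within the scatter). Compound 4 is therefore estimated at 20000 nM in this assay, with an expected range from 6000 nM to 60000 nM.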

Compound 4, concentration for 50% growth inhibition: 5590 nM
Estimate against measurement, compound 4: 3.6-fold (0.55 log units) above; measured number outside the range, below it.
By their numbers in this assay, from the lowest: compounds 4, 2 and 1 (each within the scatter of the next); then compound 3.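

In this assay, replacing phenyl with 3-isopropylphenyl gives a 6.7-fold lower number from compound 3 to compound 4 (0.83 log units; beyond the scatter). Among these compounds, this is the first reading of this position, and it shows that the position accepts isopropyl and that growth inhibition strengthens with it. Nothing available explains how this step arises.

One pair cannot tell whether the gain is particular to isopropyl. From the compounds shown here alone, a methyl, a tert-butyl or a methoxy group at the same carbon remains open, as does isopropyl on another carbon of that ring.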